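From a Propyl Amide to a 2-Methylbenzyl Amide

The source may report more compounds than this note shows. Statements on the series, on what has been measured and on what is new or still open speak of the compounds shown alone.

In a functional assay on A2780 cells (Homo sapiens) for antiproliferative activity, read by resazurin assay, with a stated time of 72 h (on this read-out higher numbers stand for weaker inhibition and lower numbers for stronger inhibition), compound 1 `CCCN(C)C(=O)c1cc2c(Cc3ccccc3)n[nH]c2cc1O` gives > 10000 nM, which is a limit of the assay and not a number. Compound 4 `Cc1ccccc1CN(C)C(=O)c1cc2c(Cc3ccccc3)n[nH]c2cc1O` differs from it as follows: 2-methylphenyl in place of ethyl on a saturated chain carbon bound to an amide-type nitrogen. That is, 2-methylphenyl stands in place of ethyl on a saturated chain carbon bound to an amide-type nitrogen. Among the measured compounds shown here, the closest measured change is the one to compound 3 `CN(Cc1ccccc1Cl)C(=O)c1cc2c(Cc3ccccc3)n[nH]c2cc1O`, with 2-chlorophenyl at that place, which gives 1100 nM. This change is an at least 9.0-fold lower number from compound 1 to compound 3 (0.95 log units; beyond the scatter). Compound 2 `CN(C(=O)c1cc2c(Cc3ccccc3)n[nH]c2cc1O)c1ccco1`, with furan-2-yl on the amide-type nitrogen, gives 2500 nM. That change is an at least 4.0-fold lower number from compound 1 to compound 2 (0.60 log units; beyond the scatter), and the remaining one is a 2.3-fold lower number from compound 2 to compound 3 (0.36 log units; beyond the scatter). A similar drop toward lower numbers is therefore expected, and the estimated step is an at least 6.6-fold lower number from compound 1 to compound 4 (0.82 log units; beyond the scatter). For compound 4 the expected value is 1500 nM, with an estimated range of 600 nM to 4000 nM.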

Compound 4, half-maximal inhibitory concentration: 4400 nM
The estimate for compound 4 lay 2.9-fold (0.47 log units) below the measured number; measured number above the stated range.
By their numbers in this assay, from the lowest: compound 3; then compounds 2 and 4 (each within the scatter of the next). At a limit, above all of these: compound 1.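

In this assay, 2-methylbenzyl also improves on propyl, though compound 1 sits at a limit of the assay, so the step is only a bound: an at least 2.2-fold lower number from compound 1 to compound 4 (0.35 log units; beyond the scatter). The gain with a benzyl-type group therefore does not depend on chloro alone, yet the ring substituent still matters, as methyl in place of chloro on an aromatic carbon gives a 4.0-fold higher number from compound 3 to compound 4 (0.60 log units; beyond the scatter). Replacing furan-2-yl with 2-methylbenzyl gives a 1.8-fold higher number from compound 2 to compound 4 (0.25 log units; within the scatter), so these two amides cannot be ordered.

The compounds shown leave open how much of the gain comes from the aromatic ring itself, which an unsubstituted benzyl group would address. They also leave open how a methoxy group would compare with chloro and methyl at this place.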